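Trading Nitro for Trifluoromethyl in a Stable Series

The source may hold more compounds than are shown below. What is called first, only, known or untested is meant among the compounds shown, and "the series" means these compounds.

In an ADME assay on microsomes from liver (Mus musculus, strain CD1) for metabolic stability, read by LC-MS, using NADPH, with a stated time of 30 min, tested at 3 uM (on this read-out higher numbers stand for a more stable compound and lower numbers for a less stable compound), compound 2 `COc1ncc(-c2ccc(-c3cnc4c(c3)CN(C)C4=O)s2)cc1NS(=O)(=O)c1ccccc1[N+](=O)[O-]` gives 95%. Compound 3 `CN1Cc2cc(-c3ccc(-c4cncc(NS(=O)(=O)c5cccc(C(F)(F)F)c5)c4)s3)cnc2C1=O` gives 88%, within the usual scatter of compound 2, while compound 1 `O=C1NCc2ncc(-c3ccc(-c4cncc(NS(=O)(=O)c5ccc(F)cc5F)c4)s3)cc21` gives 83%, lower than compound 2 by more than the scatter. Compound 4 `COc1ncc(-c2ccc(-c3cnc4c(c3)CN(C)C4=O)s2)cc1NS(=O)(=O)c1ccccc1C(F)(F)F` has not yet been measured. It differs from compound 2 in one place: trifluoromethyl in place of nitro on an aromatic carbon, ortho to a large group. Among the compounds with values here, no measured pair shows this exchange alone, so the expectation rests only on these three high values. In this assay, no step beyond the scatter is expected, with an estimated a number 5 percentage points lower from compound 2 to compound 4 (within the scatter). Compound 4 is expected to give 90%, within a range of 78% to 98%.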

Compound 4, percent of the compound remaining in the Mus musculus assay: 91%
Estimate against measurement, compound 4: 1 percentage points below; measured number inside the range.
By their numbers in the Mus musculus assay, from the lowest: compounds 1, 3, 4 and 2 (each within the scatter of the next, the first and the last beyond it).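

Compound 2 and compound 4 now give a direct reading of this exchange at this position: in the Mus musculus assay compound 2 gives 95% and compound 4 gives 91%, and trifluoromethyl in place of nitro gives a number 4 percentage points lower from compound 2 to compound 4 (within the scatter) and so does not separate the two groups. In a physicochemical assay for solubility, read by HPLC (on this read-out higher numbers stand for higher solubility and lower numbers for lower solubility), compound 2 gives 4810 ug/mL and compound 4 gives 7340 ug/mL, and the same exchange gives a 1.5-fold higher number from compound 2 to compound 4 (0.18 log units; within the scatter) and does not separate them either. Nothing available here explains why the two groups read alike. Still open, on these data alone, is how an amine or a carboxylic acid would read at this same place, and whether this exchange reads alike on the core of compound 1 .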